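The source may report more compounds than this note shows. Statements on the series, on what has been measured and on what is new or still open speak of the compounds shown alone.

Measured so far in a functional assay on CHO-K1 cells for antagonist activity at transient receptor potential cation channel subfamily V member 1 (Homo sapiens), read by FLIPR; a lower number here means a stronger inhibitor, a higher number a weaker inhibitor:
compound 1, `CCCCNc1nc(C(F)(F)F)ccc1CNC(=O)C(C)c1ccc(NS(C)(=O)=O)c(F)c1`, 9.1 nM
compound 2, `CC(C(=O)NCc1ccc(C(F)(F)F)nc1Nc1ccc(F)cc1)c1ccc(NS(C)(=O)=O)c(F)c1`, 39.2 nM
compound 3, `Cc1ccc(Cl)cc1Nc1nc(C(F)(F)F)ccc1CNC(=O)C(C)c1ccc(NS(C)(=O)=O)c(F)c1`, 14 nM

Compound 1 has the lowest number of the three. Its nearest neighbour is compound 3, with a 1.5-fold higher number from compound 1 to compound 3 (0.19 log units; within the scatter), and its furthest is compound 2, with a 4.3-fold higher number from compound 1 to compound 2 (0.63 log units; beyond the scatter). Between the two aryl-bearing compounds the gap is a 2.8-fold lower number from compound 2 to compound 3 (0.45 log units; beyond the scatter).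

Compound 4, `CC(C(=O)NCc1ccc(C(F)(F)F)nc1N(C)C)c1ccc(NS(C)(=O)=O)c(F)c1`, is the next compound for this assay. It differs from compound 1 by dimethylamino in place of butylamino on an aromatic carbon. The measured steps all start from compound 1 and exchange butyl for an aryl group; none of them replaces butylamino by dimethylamino or by any other alkyl group, so they bear on the change only in showing how far this position tolerates alteration. Those steps ranged from within the scatter, a 1.5-fold higher number from compound 1 to compound 3 (0.19 log units; within the scatter), to modest, a 4.3-fold higher number from compound 1 to compound 2 (0.63 log units; beyond the scatter). A step of similar modest size towards a higher number is expected here, a 2.7-fold higher number from compound 1 to compound 4 (0.44 log units; beyond the scatter). Compound 4 is therefore estimated at 25 nM in this assay, within 8 nM to 80 nM.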

Compound 4, inhibition constant: 19.1 nM
The estimate for compound 4 lay 1.3-fold (0.12 log units) above the measured number, and the stated range covers the measured number.
By their numbers in this assay, from the lowest: compounds 1, 3 and 4 (each within the scatter of the next, the first and the last beyond it); then compound 2.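

In this assay, going by these compounds alone, dimethylamino gives the first alkyl-for-alkyl comparison at this position, and the loss of the hydrogen-bond donor of butylamino, together with the shorter chains, amounts to only a modest step (a 2.1-fold higher number from compound 1 to compound 4 (0.32 log units; beyond the scatter)). A nitrogen without a hydrogen is therefore tolerated here, and compound 4 stays within the scatter of the aryl-bearing compound 3 (a 1.4-fold higher number from compound 3 to compound 4 (0.13 log units; within the scatter)) and beyond the scatter of the aryl-bearing compound 2 (a 2.1-fold lower number from compound 2 to compound 4 (0.31 log units; beyond the scatter)). Nothing measured here accounts for the size of these steps.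

Compound 4 changes the nitrogen hydrogen and the chain together, so their shares in the step remain unseparated. Methylamino would keep the hydrogen on a short chain, and N-methylbutylamino would remove it while keeping the butyl chain.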